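Ring Amine Substitution and Solubility in Isoxazole Amides

The compounds below may be only part of what the source reports. "The series", "measured", "known", "first", "only" and "open" are said of these compounds alone.

Among the measured compounds shown here, compound 1 `CC(C)CN1CCCC[C@H]1C(=O)Nc1cc(C(C)(C)C)on1` is the more soluble of the two compounds measured so far. In a physicochemical assay for solubility, read by HPLC, at pH 6.8 (a higher number here means a more soluble compound, a lower number a less soluble compound), compound 1 gives 32 ug/mL, the highest of the two numbers, while compound 2 `CC(C)(C)c1cc(NC(=O)[C@@H]2CCCCN2C(=O)c2ccccc2)no1` gives 0.9 ug/mL. For the measured compounds named here, the one step already measured, a 36-fold lower number from compound 1 to compound 2 (1.55 log units; beyond the scatter), shows that replacing the isobutyl on the ring amine nitrogen with an acyl group can lower the number a great deal.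

Compound 3 `CC(C)(C)c1cc(NC(=O)[C@@H]2CCCCN2C(=O)N2CCCCC2)no1` carries the change ((piperidin-1-yl)carbonyl in place of isobutyl on an amine nitrogen in a ring). This change resembles the step from compound 1 to compound 2 in that the isobutyl again gives way to a carbonyl-bearing group on the same nitrogen, although here the entering group contains a six-membered non-aromatic ring rather than a benzene ring. Given that resemblance, compound 3 is expected to show a clearly lower number than compound 1 in this assay, a step of a 6.4-fold lower number from compound 1 to compound 3 (0.81 log units; beyond the scatter), likely smaller than the step to compound 2. Compound 3 is therefore estimated at 5 ug/mL, within a range of 1.5 ug/mL to 16 ug/mL.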

Compound 3, solubility: 49 ug/mL
Compound 3: middle estimate off by 9.8-fold (0.99 log units), on the low side, and the stated range ends below it.
By their numbers in this assay, from the lowest: compound 2; then compounds 1 and 3 (each within the scatter of the next).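

The isobutyl on the amine nitrogen in a ring can give way to a group bearing a carbonyl with no readable change in this assay: the step is a 1.5-fold higher number from compound 1 to compound 3 (0.19 log units; within the scatter) and leaves compounds 1 and 3 indistinguishable. A carbonyl on this nitrogen therefore does not by itself bring the low number of compound 2, and the group on the carbonyl carbon matters a great deal, with piperidin-1-yl in place of phenyl giving a 54-fold higher number from compound 2 to compound 3 (1.74 log units; beyond the scatter) in the same assay. Nothing at hand bears on why these two groups on the carbonyl carbon stand so far apart.

The compounds shown do not separate the ring nitrogen of piperidin-1-yl from the non-aromatic ring as such. The step from compound 2 to compound 3 alters both at once.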